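Adding a fluoro to the phenyl of compound 2

This account rests on a few compounds, and the source may have more. Where it says the series, first, only, none or still open, it means among the compounds named here.

Measured so far in a functional assay on HCT-116 cells (Homo sapiens) for inhibition, with a stated time of 72 h; a higher number here means a weaker inhibitor, a lower number a stronger inhibitor:
Compound 1 `NC1CCC(Nc2nc(NCc3ccc(-c4ccsc4)cc3)c3ncn(C4CCCC4)c3n2)CC1` gives 315 nM
Compound 2 `NC1CCC(Nc2nc(NCc3ccc(-c4ccccc4)nc3)c3ncn(C4CCCC4)c3n2)CC1` gives 563 nM

These two values lie within the scatter of each other, so compound 2 stands level with compound 1 on the numbers available. Compound 3 `NC1CCC(Nc2nc(NCc3ccc(-c4cccc(F)c4)nc3)c3ncn(C4CCCC4)c3n2)CC1` differs from compound 2 by fluoro in place of hydrogen on an aromatic carbon on the phenyl, which becomes 3-fluorophenyl. For the measured compounds named here, only one measured step bears on this, and only loosely. The step of a 1.8-fold higher number from compound 1 to compound 2 (0.25 log units; within the scatter) replaced a whole 4-(thiophen-3-yl)phenyl with 6-phenylpyridin-3-yl and stayed within the scatter. Going by the values given here, no measured step tests a fluoro, so the data give no direction for this smaller change. The expected step of a 1.2-fold lower number from compound 2 to compound 3 (0.07 log units; within the scatter) is estimated to stay within the scatter. Compound 3 is estimated at 480 nM with an expected range from 200 nM to 1200 nM in this account.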

Compound 3, half-maximal inhibitory concentration: 74 nM
The estimate for compound 3 lay 6.5-fold (0.81 log units) above the measured number; measured number outside the range, below it.
By their numbers in this assay, from the lowest: compound 3; then compounds 1 and 2 (each within the scatter of the next).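

Going from phenyl to 3-fluorophenyl in this assay gives a 7.6-fold lower number from compound 2 to compound 3 (0.88 log units; beyond the scatter), so this aromatic carbon, meta to a large group, responds to the addition of a single fluorine atom. For the compounds shown here, the earlier compounds could not show this: their one step, a 1.8-fold higher number from compound 1 to compound 2 (0.25 log units; within the scatter), exchanged a whole 4-(thiophen-3-yl)phenyl for 6-phenylpyridin-3-yl and stayed within the scatter, while here a far smaller change moves the number beyond it. No information at hand accounts for the size of this step.

The compounds shown leave open whether the gain is particular to fluoro or would also appear with a chloro, a methoxy or an amine on the same carbon. They also leave open whether the same fluoro would have a similar effect on any other carbon of the phenyl.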